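Thiosemicarbazone series: expectation for the furan-2-yl analogue

The compounds below may be only part of what the source reports. "The series", "measured", "known", "first", "only" and "open" are said of these compounds alone.

Measured so far in a functional assay on 786-0 cells (Homo sapiens) for inhibition, read by sulforhodamine B assay, with a stated time of 48 h; on this read-out higher numbers stand for weaker inhibition of growth and lower numbers for stronger inhibition of growth:
compound 1 `CC1=CC[C@H](C(C)(C)NC(=S)N/N=C/c2ccc(O)cc2)CC1` gives > 100000 nM, a limit of the assay.
compound 2 `CC1=CC[C@H](C(C)(C)NC(=S)N/N=C/c2ccccc2Cl)CC1` gives > 100000 nM, a limit of the assay.
compound 3 `CC1=CC[C@H](C(C)(C)NC(=S)N/N=C/c2cccc(Cl)c2)CC1` gives 26900 nM.

Among the compounds with values here, compound 3 holds the only number in this assay; the two other values are limits (the limit of > 100000 nM in this assay, at which 2 of the 3 values shown sit). The steps into compound 3 are both at least modest: an at least 3.7-fold lower number from compound 1 to compound 3 (0.57 log units; beyond the scatter) and an at least 3.7-fold lower number from compound 2 to compound 3 (0.57 log units; beyond the scatter). The step between the two limits cannot be read: a step that the two limits leave unreadable from compound 1 to compound 2.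

Compound 4 `CC1=CC[C@H](C(C)(C)NC(=S)N/N=C/c2ccco2)CC1` differs from compound 3 by furan-2-yl in place of 3-chlorophenyl on a carbon with a double bond to nitrogen. Within the data shown here, no measured step exchanges the six-membered aromatic ring for a five-membered one; the measured steps bear on this change only loosely. They show that the group on the carbon with a double bond to nitrogen can move the number by at least a modest amount, and that two of three such groups give only a limit in this assay. For compound 4 the expected step of a 2.2-fold higher number from compound 3 to compound 4 (0.35 log units; beyond the scatter) is towards a higher number, with a real chance that this assay returns only a limit. Compound 4 is estimated at 60000 nM, within 20000 nM to 150000 nM.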

Compound 4, concentration for total growth inhibition: 9800 nM
Compound 4: middle estimate off by 6.1-fold (0.79 log units), on the high side; measured number below the stated range.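

In this assay, furan-2-yl on a carbon with a double bond to nitrogen gives a 2.7-fold lower number from compound 3 to compound 4 (0.44 log units; beyond the scatter), so a six-membered aromatic ring of carbon only is not required at this place for a measurable value, and a five-membered aromatic ring with 1 hetero atom can give a lower number than 3-chlorophenyl. Against the other two groups, the change gives an at least 10-fold lower number from compound 2 to compound 4 (1.00 log units; beyond the scatter) and an at least 10-fold lower number from compound 1 to compound 4 (1.00 log units; beyond the scatter); both are bounds rather than sizes, and compound 4 now has the lowest number of the four compounds, with every step to it beyond the scatter. Only compound 3 and compound 4 give numbers at this place, and the other two remain at a limit: the limit of > 100000 nM in this assay, at which 2 of the 4 values shown sit.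

The compounds shown leave open whether the ring size or the ring oxygen goes with the lower number, a question that a thienyl or pyrrolyl group at the same place would bear on directly. Also open, on these data alone, is whether a methyl group on the furan ring or a pyridyl ring in its place would keep the number, and the step between compound 1 and compound 2 cannot be read.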